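The source may hold more compounds than are shown below. What is called first, only, known or untested is meant among the compounds shown, and "the series" means these compounds.

Measured in a functional assay on A-375 cells (Homo sapiens) for activation, with a stated time of 3 days; on this read-out lower numbers stand for an effect already at smaller amounts and higher numbers for an effect only at larger amounts of compound:
Compound 1 `O=C(Nc1ccc(-c2cscn2)cc1)C1CCCN(Cc2cccc(F)c2)C1` gives 5000 nM
Compound 2 `O=C(Nc1ccc(-c2cscn2)cc1)C1CCCN(Cc2cc(F)cc(F)c2)C1` gives 1500 nM
Compound 3 `O=C(Nc1ccc(-c2cscn2)cc1)C1CCCN(Cc2cccc(C(F)(F)F)c2)C1` gives > 20000 nM as a limit

Compound 3 is the weakest of the three, and it has no number of its own. Its entry is the limit of > 20000 nM in this assay, at which 1 of the 3 values shown sits, and this is a limit.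

Compound 4 `O=C(Nc1ccc(-c2cscn2)cc1)C1CCCN(Cc2cccnc2)C1` has yet to be measured. It carries pyridin-3-yl in place of 3-(trifluoromethyl)phenyl on a saturated chain carbon bound to an amine nitrogen in a ring, counted as pyridin-3-yl in place of 3-(trifluoromethyl)phenyl on a saturated chain carbon bound to an amine nitrogen in a ring here.

Among the measured compounds shown here, no measured step makes this exact exchange, but three steps on the same aromatic group bear on it. Fluoro in place of hydrogen on an aromatic carbon gave a 3.3-fold lower number from compound 1 to compound 2 (0.52 log units; beyond the scatter) here. Trifluoromethyl in place of fluoro on an aromatic carbon gave an at least 4.0-fold higher number from compound 1 to compound 3 (0.60 log units; beyond the scatter) here, and the remaining comparison gave an at least 13-fold higher number from compound 2 to compound 3 (1.12 log units; beyond the scatter) here. These steps run from modest to large, and only the compound with trifluoromethyl lost its number.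

On these data alone, compound 4 lacks that group, so a step of modest size towards a lower number is expected in this assay, though its true size stays open. The expected step is an at least 2.8-fold lower number from compound 3 to compound 4 (0.45 log units; beyond the scatter) in this estimate. For compound 4 the estimate is 7000 nM, with an expected range from 2000 nM to 20000 nM as its ends.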

Compound 4, half-maximal effective concentration: > 20000 nM
Compound 4 ended at the assay's limit; the forecaster's own chance of this, stated with the estimate: 30%; at least 2.8-fold (0.45 log units) between middle value and limit.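

In this assay, among the compounds shown here, compound 4 has only a limit, > 20000 nM, and not a number, so trifluoromethyl is not the only group at this place on a saturated chain carbon bound to an amine nitrogen in a ring that ends without a measured value: the limit of > 20000 nM in this assay, at which 2 of the 4 values shown sit. The exchange of 3,5-difluorophenyl for pyridin-3-yl gives an at least 13-fold higher number from compound 2 to compound 4 (1.12 log units; beyond the scatter), and the exchange of 3-fluorophenyl for pyridin-3-yl gives an at least 4.0-fold higher number from compound 1 to compound 4 (0.60 log units; beyond the scatter). Among the compounds shown, only the two with fluoro-substituted phenyl groups, compound 1 and compound 2, keep a number, while the step between compound 3 and compound 4 cannot be read, as both entries are limits.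

The compounds shown leave open how far compound 3 and compound 4 really lie from each other, and whether the ring nitrogen of pyridin-3-yl or the missing fluoro groups matter more for the result. They also leave open whether a chloro or methoxy group on the phenyl ring, or a third fluoro group, would keep a number in this assay or move it further down than in compound 2.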